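The source may hold more compounds than are shown below. What is called first, only, known or untested is meant among the compounds shown, and "the series" means these compounds.

Measured so far:
- compound 1 `CC(C)(C)OC(=O)N1CCC(O[C@H]2CC[C@H](Oc3ccc(S(C)(=O)=O)cc3F)CC2)CC1`, 113% in a functional assay on isolated protein for agonist activity at Glucose-dependent insulinotropic receptor (Homo sapiens), read by HTRF and cAMP accumulation; on this read-out lower numbers stand for smaller maximal responses and higher numbers for larger maximal responses
- compound 2 `CC1(OC(=O)N2CCC(O[C@H]3CC[C@H](Oc4cnc(S(C)(=O)=O)cn4)CC3)CC2)CC1`, 118% in this assay

Compound 2 and compound 1 sit within the scatter of each other in this assay, so the two numbers tell the same story: both reach a full response against the reference, and no ordering between them can be read.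

Compound 3 `CS(=O)(=O)c1cnc(O[C@H]2CC[C@H](OC3CCN(C(=O)Oc4ccccc4)CC3)CC2)cn1` has not been measured. It differs from compound 2 in one place: phenyl in place of 1-methylcyclopropyl on an oxygen next to a carbonyl group. Going by the values given here, no step between measured compounds touches this position, so the size of the change is unknown. Given that both measured compounds hit the ceiling of the response, the step from compound 2 to compound 3 is expected to be small, a number 10 percentage points lower from compound 2 to compound 3 (within the scatter), within the scatter and if anything downward. Compound 3 is estimated at 108%, between 90% and 125% in this assay.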

Compound 3, largest response reached (Emax), in percent of the reference or control that the assay uses: 116%
Estimate against measurement, compound 3: 8 percentage points below, within the range that was stated.
By their numbers in this assay, from the lowest: compounds 1, 3 and 2 (each within the scatter of the next).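

Phenyl in place of 1-methylcyclopropyl on an oxygen next to a carbonyl group gives a number 2 percentage points lower from compound 2 to compound 3 (within the scatter) in this assay. Going by these compounds alone, this step is the first reading at this position, and on this read-out it does not separate a three-membered non-aromatic ring from a six-membered aromatic ring of carbon only, despite the larger heavy-atom count of phenyl. Nothing available explains this result. Open, going by these compounds, is whether a group carrying an amine or a carboxylic acid at this position leaves the maximal response in the same range. On these data alone, a longer alkyl chain on this oxygen is equally open.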